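The source may hold more compounds than are shown below. What is called first, only, known or untested is meant among the compounds shown, and "the series" means these compounds.

Of the compounds shown here, three built on one shared core have been measured in a functional assay on HL-60 cells (Homo sapiens) for antiproliferative activity, with a stated time of 24 h; on this read-out lower numbers stand for stronger inhibition and higher numbers for weaker inhibition. Compound 1 `NC(=O)c1c(NC(=O)c2ccccc2Cl)sc2c1CCN(Cc1ccc([N+](=O)[O-])cc1)C2` gives 11400 nM, compound 2 `NC(=O)c1c(NC(=O)c2ccccc2Cl)sc2c1CCN(Cc1c(Cl)cccc1Cl)C2` gives 4850 nM, and compound 3 `COc1ccc(NC(=S)N2CCc3c(sc(NC(=O)c4ccccc4Cl)c3C(N)=O)C2)cc1` gives 15700 nM, the highest number of the three. Compound 4 `NC(=O)c1c(NC(=O)c2ccccc2Cl)sc2c1CCN(C(=S)Nc1c(Cl)cccc1Cl)C2` differs from compound 3 by 2,6-dichlorophenyl in place of 4-methoxyphenyl on an amide-type nitrogen. The closest measured comparison is a 2.4-fold lower number from compound 1 to compound 2 (0.37 log units; beyond the scatter), where the same 2,6-dichlorophenyl entered at a different place; in the step of a 3.2-fold higher number from compound 2 to compound 3 (0.51 log units; beyond the scatter) that group was lost again. A modest downward step is therefore expected for compound 4, a 2.2-fold lower number from compound 3 to compound 4 (0.35 log units; beyond the scatter), beyond the scatter but not large. The estimate for compound 4 is 7000 nM, with a range from 3000 nM to 16000 nM.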

Compound 4, half-maximal inhibitory concentration: 3950 nM
Compound 4: middle estimate off by 1.8-fold (0.25 log units), on the high side, within the range that was stated.
By their numbers in this assay, from the lowest: compounds 4 and 2 (each within the scatter of the next); then compounds 1 and 3 (each within the scatter of the next).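

On the amide-type nitrogen, the ring matters in this assay: 2,6-dichlorophenyl in place of 4-methoxyphenyl gives a 4.0-fold lower number from compound 3 to compound 4 (0.60 log units; beyond the scatter). The same dichlorinated ring on the thiocarbonyl link leaves compound 4 level with compound 2, at a 1.2-fold lower number from compound 2 to compound 4 (0.09 log units; within the scatter), while the change against the nitrophenyl compound is a 2.9-fold lower number from compound 1 to compound 4 (0.46 log units; beyond the scatter). Nothing measured here explains these steps.

A plain phenyl or a 4-chlorophenyl on this nitrogen would help separate the part played by the two chlorines from that of losing the methoxy group.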